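A few compounds are considered here, and "the series" means these few. Any claim that something is new, unique, unknown or untested is made for them only; others in the source may bear on it.

Three structures share a long chain that ends in a five-membered aromatic ring with one nitrogen carrying a methyl group. Compound 1 `Cc1ccc(-c2ccccc2)n1CCCCCCNC(=O)Oc1ccccc1` bears a single phenyl group on that ring, and in an assay on microsomes from brain (strain Sprague-Dawley) for inhibition of Fatty-acid amide hydrolase 1 (Rattus norvegicus), read by fluorescence and HPLC, with stated times of 10 min and 60 min (on this read-out higher numbers stand for weaker inhibition and lower numbers for stronger inhibition), compound 1 gives 310 nM. Compound 2 `COC(=O)c1c(-c2ccccc2)c(-c2ccccc2)n(CCCCCCNC(=O)Oc2ccccc2)c1C` carries two phenyl groups and a methoxycarbonyl group. In this assay compound 2 reaches only the limit of the assay, > 10000 nM; this is the limit of > 10000 nM in this assay, at which 1 of the 2 values shown sits. Compound 3 `Cc1cc(-c2ccccc2)c(-c2ccccc2)n1CCCCCCNC(=O)Oc1ccccc1` is compound 2 with one group removed: hydrogen in place of methoxycarbonyl on an aromatic carbon. Among the compounds with values here, no measured step of this kind exists here. Compound 1, which lacks the methoxycarbonyl group, gives 310 nM in this assay. The expected step from compound 2 to compound 3 is therefore an at least 11-fold lower number from compound 2 to compound 3 (1.04 log units; beyond the scatter), a gain beyond the usual scatter. Compound 3 is estimated at 900 nM in this assay, with a likely range from 150 nM to 5000 nM.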

Compound 3, half-maximal inhibitory concentration: 2600 nM
Beside the measured number, compound 3's estimate is 2.9-fold (0.46 log units) below it; the range from low to high includes it.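

In this assay, within the data shown here, hydrogen in place of methoxycarbonyl on this aromatic carbon gives an at least 3.8-fold lower number from compound 2 to compound 3 (0.58 log units; beyond the scatter), the first measured change at this position, and it shows that the methoxycarbonyl group goes with weaker inhibition on this core. Compound 2 stands at a limit and not at a number, so the true step may be larger: the limit of > 10000 nM in this assay, at which 1 of the 3 values shown sits.

Taking the methoxycarbonyl group away does not bring inhibition back to the level of the one-phenyl compound, as phenyl in place of hydrogen on an aromatic carbon gives an 8.4-fold higher number from compound 1 to compound 3 (0.92 log units; beyond the scatter).

On these data alone, how the aromatic carbon that held the methoxycarbonyl group would respond to a carboxylic acid, an amine or a methyl group remains open. The compounds shown also leave open whether removing the second phenyl group from compound 2 would have any effect while the methoxycarbonyl group stays in place.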